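The source may hold more compounds than are shown below. What is called first, only, known or untested is meant among the compounds shown, and "the series" means these compounds.

In an ADME assay on MT4 cells (Homo sapiens) for cytotoxicity, read by MTT assay (a higher number here means that more compound is tolerated, a lower number that less compound is tolerated), compound 3 `O=C(CSc1nc(Cc2c(Cl)cccc2Cl)cc(=O)[nH]1)c1ccccc1` has no exact number, only the limit > 12000 nM. Compound 4 `Cc1c(Cc2c(Cl)cccc2Cl)nc(SCC(=O)c2ccccc2)[nH]c1=O` differs from it by a single change, (methyl in place of hydrogen on an aromatic carbon), which puts methyl in place of hydrogen on an aromatic carbon. Within the data shown here, no measured step makes this exact change, but two relatives carry the same methyl on the shared core, with a different side chain on the sulfur. Compound 1 `COc1ccc(CSc2nc(Cc3c(Cl)cccc3Cl)c(C)c(=O)[nH]2)cc1` gives 32000 nM. Compound 2 `COc1ccc(CCSc2nc(Cc3c(Cl)cccc3Cl)c(C)c(=O)[nH]2)cc1` reaches only a limit, > 57000 nM. Among the measured compounds shown here, the one measured step, an at least 1.7-fold higher number from compound 1 to compound 2 (0.25 log units; that floor lies within the scatter), concerns that side chain and not the methyl, so it offers only indirect guidance. With compound 1 at 32000 nM as the nearest exact number, compound 4 is expected to be tolerated at a similar level, and the methyl itself is not expected to cause a change beyond the scatter. The estimated step is a step that the limit leaves unreadable from compound 3 to compound 4, though it is reckoned from a limit and not from a true number. For compound 4 the expected value is 30000 nM, with an estimated range from 13000 nM to 70000 nM.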

Compound 4, half-maximal cytotoxic concentration: > 60000 nM
Compound 4: a limit, no number; the forecaster's own chance of this, stated with the estimate: 45%; middle value at least 2.0-fold (0.30 log units) from the limit.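

In this assay, the methyl on the aromatic carbon, with benzoyl on the sulfur-bound chain, still leaves no exact number: compound 4 gives only a limit, > 60000 nM. Among these compounds, the steps from compound 3 to compound 4 and from compound 2 to compound 4 cannot be read, because compound 4 stands at a limit, as do compound 2 and compound 3: the limit of > 60000 nM in this assay, at which 1 of the 4 values shown sits. The one readable step is an at least 1.8-fold higher number from compound 1 to compound 4 (0.27 log units; that floor lies within the scatter), and it sets benzoyl in place of 4-methoxyphenyl on a saturated chain carbon bound to a sulfur.

From the compounds shown here alone, the size of the methyl's own effect stays open, since neither compound 3 nor compound 4 has an exact value. Also open, going by these compounds, is whether an ethyl or an amine in place of this methyl would give a number different from these limits.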